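The source may hold more compounds than are shown below. What is called first, only, known or untested is meant among the compounds shown, and "the series" means these compounds.

Measured compounds in a functional assay on CRL2813 cells (Homo sapiens) for cytotoxicity, read by sulforhodamine B assay, with a stated time of 5 days; on this read-out higher numbers stand for weaker inhibition and lower numbers for stronger inhibition:

Compound 1 `O=C(Nc1cccc(C(F)(F)F)c1)N[C@H]1CC[C@H](Oc2cccc(F)c2)CC1` gives 2400 nM.
Compound 2 `Cc1ccc(NC(=O)N[C@H]2CC[C@H](Oc3ccc(F)cc3)CC2)cc1` gives a limit, > 20000 nM.
Compound 3 `O=C(Nc1cccc(C(F)(F)F)c1)N[C@H]1CC[C@H](O)CC1` gives a limit, > 20000 nM.

Compound 2 thus stands at the limit of this assay, as stated in the limit of > 20000 nM in this assay, at which 2 of the 3 values shown sit; no number is known for it, only that it lies past the reach of the assay. Going by the values given here, compound 1, which carries a trifluoromethyl on its aryl and a 3-fluorophenyl on the oxygen, is the only compound with a measured number.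

Among the compounds with values here, the one measured step, an at least 8.3-fold higher number from compound 1 to compound 3 (0.92 log units; beyond the scatter), concerns the oxygen on the saturated carbon and not the amide-type nitrogen, so it does not bear directly on the present change. Compound 4 `O=C(Nc1cccc(Br)c1)N[C@H]1CC[C@H](Oc2ccc(F)cc2)CC1` differs from compound 2 as follows: 3-bromophenyl in place of 4-methylphenyl on an amide-type nitrogen. What can be said rests on the values alone: compound 1 with a 3-substituted aryl on that nitrogen gives a measured number, compound 2 with 4-methylphenyl sits at the limit.

For compound 4 a move below the limit is expected, an at least 4.4-fold lower number from compound 2 to compound 4 (0.64 log units; beyond the scatter), with considerable uncertainty since the limit gives no starting number. The estimate for compound 4 is 4500 nM, within 1500 nM to 20000 nM.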

Compound 4, half-maximal inhibitory concentration: 6200 nM
Compound 4: middle estimate off by 1.4-fold (0.14 log units), on the low side; low and high end bracket the measured number.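

In this assay, going by these compounds alone, the change on the amide-type nitrogen gives the first measured step at this position: an at least 3.2-fold lower number from compound 2 to compound 4 (0.50 log units; beyond the scatter). With 3-bromophenyl on that nitrogen and the 4-fluorophenyl group kept on the oxygen, the shared core gives a measurable number, so a limit is not the only outcome for this oxygen substituent. Compound 2 remains a limit and not a number, so the step gives only a minimum size and its full extent is unknown: the limit of > 20000 nM in this assay, at which 2 of the 4 values shown sit.

The step also replaces methyl with bromine and moves the substituent on the phenyl ring in a single change, so the compounds shown cannot separate the identity of the substituent from its place, and 3-methylphenyl and 4-bromophenyl on the same nitrogen would be the pair needed to do so. Also open, going by these compounds, is how the series would read in this assay with an amine or a carboxylic acid on that phenyl ring, or with a longer chain in place of the ring on the amide-type nitrogen.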